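Chloro for methoxy on the aryl hydrazone of compound 1

A few compounds are considered here, and "the series" means these few. Any claim that something is new, unique, unknown or untested is made for them only; others in the source may bear on it.

Compound 1 `COc1ccc(/C=N/NC(=S)NC(C)(C)[C@H]2CC=C(C)CC2)cc1`: 29600 nM
Compound 2 `CC1=CC[C@H](C(C)(C)NC(=S)N/N=C/c2ccc(F)cc2)CC1`: > 100000 nM
Compound 3 `CC1=CC[C@H](C(C)(C)NC(=S)N/N=C/c2cccc(Cl)c2)CC1`: 26900 nM

In a functional assay on 786-0 cells (Homo sapiens) for inhibition, read by sulforhodamine B assay, with a stated time of 48 h (a higher number here means a weaker inhibitor of growth, a lower number a stronger inhibitor of growth), compound 1 gives 29600 nM, the highest of the two plain numbers, with compound 3 nearest at 26900 nM, a gap described as a 1.1-fold lower number from compound 1 to compound 3 (0.04 log units; within the scatter). For compound 2 this assay reports only a limit, > 100000 nM (the limit of > 100000 nM in this assay, at which 1 of the 3 values shown sits). Compound 4 `CC1=CC[C@H](C(C)(C)NC(=S)N/N=C/c2ccc(Cl)cc2)CC1` differs from compound 1 by chloro in place of methoxy on an aromatic carbon. Among the compounds with values here, two steps bear on it: an at least 3.3-fold higher number from compound 1 to compound 2 (0.52 log units; beyond the scatter), and an at least 3.7-fold lower number from compound 2 to compound 3 (0.57 log units; beyond the scatter), while the change to compound 3 stayed within the scatter. A halogen on that aromatic carbon thus weakened inhibition in the one case measured, so compound 4 is expected to be a somewhat weaker inhibitor, with a 1.5-fold higher number from compound 1 to compound 4 (0.18 log units; within the scatter). Compound 4 is estimated at 45000 nM, in the range 15000 nM to 130000 nM.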

Compound 4, concentration for total growth inhibition: > 100000 nM
Compound 4 ended at the assay's limit; the forecaster's own chance of this, stated with the estimate: 30%; middle value at least 2.2-fold (0.34 log units) away from the limit.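

In this assay the result for compound 4 is a limit and not a number, one it shares with compound 2: the limit of > 100000 nM in this assay, at which 2 of the 4 values shown sit. With chloro on the aromatic carbon para to a large group, growth inhibition is again weaker than with methoxy, an at least 3.3-fold higher number from compound 1 to compound 4 (0.52 log units; beyond the scatter), so a second halogen there goes the same way as fluoro. Placement of the chloro also matters, an at least 3.7-fold higher number from compound 3 to compound 4 (0.57 log units; beyond the scatter), while the step between the two halogens cannot be read.

Left open is whether an amine or a hydroxyl on that aromatic carbon would retain the inhibition seen with methoxy. Also open, going by these compounds, is how 3-methoxyphenyl or 3-fluorophenyl would compare with 3-chlorophenyl.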